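The source may hold more compounds than are shown below. What is called first, only, known or untested is meant among the compounds shown, and "the series" means these compounds.

Working notes on the series.

The shared core is carried by compound 1 `Nc1scc(CN2CCN(c3cc(Cl)cc(Cl)c3)CC2)c1C(=O)c1ccc(Cl)cc1`, compound 2 `Nc1scc(CN2CCN(c3ccc(F)cc3Cl)CC2)c1C(=O)c1ccc(Cl)cc1` and compound 3 `Nc1scc(CN2CCN(c3ccc(Cl)cc3F)CC2)c1C(=O)c1ccc(Cl)cc1`, which differ only in the aryl group on the ring amine nitrogen. In a functional assay on CHO cells with adenosine receptor A1 (Homo sapiens) as the target, read by cAMP accumulation and immunoassay, with a stated time of 6 min, tested at 0.1 uM (a higher number here means a weaker effect of the compound at the concentration tested, a lower number a stronger effect), compound 1 gives -22%, compound 2 gives -6.2% and compound 3 gives -9.4%. Compound 3 thus sits second highest of the three numbers; its nearest neighbour is compound 2, within the scatter, and its furthest is compound 1, beyond the scatter.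

The next compound is compound 4 `COc1ccc(N2CCN(Cc3csc(N)c3C(=O)c3ccc(Cl)cc3)CC2)cc1`, with the change (4-methoxyphenyl in place of 4-chloro-2-fluorophenyl on an amine nitrogen in a ring). The steps that touch the same place are a number 15.8 percentage points higher from compound 1 to compound 2 (beyond the scatter) and a number 12.6 percentage points higher from compound 1 to compound 3 (beyond the scatter), both modest, while a number 3.2 percentage points lower from compound 2 to compound 3 (within the scatter) stays within the scatter. Among the compounds with values here, no measured step exchanges a halogenated phenyl for a methoxyphenyl, so the direction of this change is not fixed by the data; the two steps from compound 1 show only modest movement at this ring. For compound 4 a step of a number 4.4 percentage points higher from compound 3 to compound 4 (within the scatter) is expected, that is, nothing beyond the scatter. Compound 4 is estimated at -5%, with a range from -25% to 15%.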

Compound 4, a percentage reported as activity, at one concentration (the size of the read-out at that concentration, not a potency): 0%
Beside the measured number, compound 4's estimate is 5 percentage points below it; measured number inside the range.
By their numbers in this assay, from the lowest: compound 1; then compounds 3, 2 and 4 (each within the scatter of the next).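

In this assay the exchange of the halogenated aryl groups for 4-methoxyphenyl on the ring amine nitrogen gives a number 9.4 percentage points higher from compound 3 to compound 4 (within the scatter) and a number 6.2 percentage points higher from compound 2 to compound 4 (within the scatter), so this position accepts an aryl group with no halogen and an oxygen-bearing substituent without a change that can be read against either compound. Within the data shown here, only the step from the 3,5-dichlorophenyl group stands out, as a number 22 percentage points higher from compound 1 to compound 4 (beyond the scatter), which leaves compound 1 as the one member of the four set apart from compound 4. Nothing available on these compounds gives a reason for this outcome.

As far as these compounds go, whether compound 1 stands apart through its pair of chlorines or through where they sit remains open. An unsubstituted phenyl, or a phenyl carrying an amine or a carboxylic acid, on this nitrogen would extend the comparison.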